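A few compounds are considered here, and "the series" means these few. Any claim that something is new, unique, unknown or untested is made for them only; others in the source may bear on it.

In a functional assay on KM12 cells (Homo sapiens) for inhibition, read by sulforhodamine B assay, with a stated time of 48 h, tested at 10 uM (on this read-out lower numbers stand for a stronger effect and higher numbers for a weaker effect at the one concentration tested), compound 3 `COc1cc2cc(Oc3ccc(NC(=O)Nc4cccc(C(F)(F)F)c4)cc3)c(C)nc2cc1OC` gives -10.2%, the lowest of the three numbers and therefore the strongest effect among the measured compounds. Compound 1 `COc1cc2cc(Oc3ccc(NC(=O)Nc4ccccc4)cc3)c(C)nc2cc1OC` gives 70.3% and compound 2 `COc1cc2cc(Oc3ccc(NC(=O)Nc4ccc(C)cc4)cc3)c(C)nc2cc1OC` gives 104%. The three differ only at the six-membered aromatic ring of carbon only on the amide-type nitrogen: a number 33.7 percentage points higher from compound 1 to compound 2 (beyond the scatter), a number 80.5 percentage points lower from compound 1 to compound 3 (beyond the scatter) and a number 114.2 percentage points lower from compound 2 to compound 3 (beyond the scatter). Compound 4 `COc1cc2cc(Oc3ccc(NC(=O)Nc4ccc(Cl)c(C(F)(F)F)c4)cc3)c(C)nc2cc1OC` differs from compound 3 by chloro in place of hydrogen on an aromatic carbon, ortho to a trifluoromethyl group and para to a large group. Among the compounds with values here, no measured step involves a chloro group, so none bears directly on this change; the steps show only that changes on that ring move the read-out by large amounts in either direction. Because compound 3 already gives -10.2%, only a small further step is expected: a number 4.8 percentage points lower from compound 3 to compound 4 (within the scatter). The estimate for compound 4 in this assay is -15%, with a range from -40% to 15%.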

Compound 4, a percentage reported as activity, at one concentration (the size of the read-out at that concentration, not a potency): -16.4%
Compound 4: middle estimate off by 1.4 percentage points, on the high side; the range from low to high includes it.
By their numbers in this assay, from the lowest: compounds 4 and 3 (each within the scatter of the next); then compound 1; then compound 2.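

In this assay, chloro in place of hydrogen on the aromatic carbon ortho to a trifluoromethyl group and para to a large group leaves the read-out unmoved on this ring, with a number 6.2 percentage points lower from compound 3 to compound 4 (within the scatter) as its step. The 4-chloro-3-(trifluoromethyl)phenyl group therefore stays far from the unsubstituted phenyl and the 4-methylphenyl groups, with a number 86.7 percentage points lower from compound 1 to compound 4 (beyond the scatter) and a number 120.4 percentage points lower from compound 2 to compound 4 (beyond the scatter) as the two large steps. Nothing available explains why this addition changes so little.

The compounds shown leave open what chloro does at this place on a ring without trifluoromethyl, since compound 4 shows it only alongside that group. They also leave open whether a methoxy group, an amine or a nitrile at the same place would keep the read-out there or shift it as far as the earlier changes on this ring did.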